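The source may report more compounds than this note shows. Statements on the series, on what has been measured and on what is new or still open speak of the compounds shown alone.

Compound 3 `c1ccc2c(c1)CC2CCCN1CCN(c2cccc3c2OCCO3)CC1` stands lowest of the three numbers in an assay on isolated protein for binding affinity to 5-hydroxytryptamine receptor 1B (Rattus norvegicus) (on this read-out higher numbers stand for weaker inhibition and lower numbers for stronger inhibition), where compound 3 gives 646 nM. Its nearest neighbour is compound 2 `Clc1cccc2c1CC2CCCN1CCN(c2cccc3c2OCCO3)CC1`, which gives 1100 nM; the step of a 1.7-fold lower number from compound 2 to compound 3 (0.23 log units; within the scatter) is within the scatter, so no order between the two is claimed. Compound 1 `c1ccc2c(c1)CC(CCCN1CCN(c3cccc4c3OCCO4)CC1)C2` gives 1860 nM, and the step of a 2.9-fold lower number from compound 1 to compound 3 (0.46 log units; beyond the scatter) is beyond the scatter. The step of a 1.7-fold lower number from compound 1 to compound 2 (0.23 log units; within the scatter) is within the scatter.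

Compound 4 `C1=C(CCN2CCN(c3cccc4c3OCCO4)CC2)Cc2ccccc21` has not been measured. Relative to compound 3 the change is a group of 9 heavy atoms (9 carbon; one five-membered non-aromatic ring of carbon only, one six-membered aromatic ring of carbon only) in place of a group of 9 heavy atoms (9 carbon; one four-membered non-aromatic ring of carbon only, one six-membered aromatic ring of carbon only), on a saturated chain carbon, two bonds along the chain from an amine nitrogen in a ring. The measured step that bears on it is a 2.9-fold lower number from compound 1 to compound 3 (0.46 log units; beyond the scatter), in which a group with a five-membered non-aromatic ring gave way to one with a four-membered non-aromatic ring; compound 4 returns to a group with a five-membered non-aromatic ring, now carrying one double bond outside aromatic rings and sitting two bonds along the chain from an amine nitrogen in a ring. Among the compounds with values here, no measured pair tests that shift in place, so the reading rests on compound 1 alone, and the reversal is expected only in part. The expected step is a 1.9-fold higher number from compound 3 to compound 4 (0.27 log units; within the scatter), a modest rise in the number. For compound 4 the estimate is 1200 nM, within a range of 400 nM to 3600 nM.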

Compound 4, inhibition constant: 933 nM
Beside the measured number, compound 4's estimate is 1.3-fold (0.11 log units) above it; measured number inside the range.
By their numbers in this assay, from the lowest: compounds 3, 4, 2 and 1 (each within the scatter of the next, the first and the last beyond it).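

In this assay the group with a five-membered non-aromatic ring and one double bond outside aromatic rings, on a saturated chain carbon, two bonds along the chain from an amine nitrogen in a ring, cannot be told apart from the group with a four-membered non-aromatic ring (step: a 1.4-fold higher number from compound 3 to compound 4 (0.16 log units; within the scatter)). The earlier group with a five-membered non-aromatic ring did stand apart (step: a 2.9-fold lower number from compound 1 to compound 3 (0.46 log units; beyond the scatter)), so in these compounds a five-membered non-aromatic ring does not by itself fix the reading. Ring size, the double bond and the place of attachment all change together in the new step, and no measurement shown separates them or accounts for the result.

It remains open which of these three features matters, since no pair shown varies the double bond or the place of attachment alone. Also open, on these data alone, is how a methoxy group on the six-membered aromatic ring, or a longer chain to the amine nitrogen, would read in this assay.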